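Cyclopropylmethoxy for ethoxy on a second core

The source may hold more compounds than are shown below. What is called first, only, known or untested is meant among the compounds shown, and "the series" means these compounds.

Compound 1 `CCOc1ccc(C)c(-c2cccc(COc3ccc(OCC(=O)O)c(F)c3)c2)c1` gives 220 nM in a functional assay on CHO cells for agonist activity at Free fatty acid receptor 1 (Homo sapiens), read by FLIPR and calcium flux; on this read-out higher numbers stand for an effect only at larger amounts of compound and lower numbers for an effect already at smaller amounts. Compound 2 `Cc1ccc(OCC2CC2)cc1-c1cccc(COc2ccc(OCC(=O)O)c(F)c2)c1` carries cyclopropyl in place of methyl on a saturated chain carbon bound to an oxygen on an aromatic ring and in this assay compound 2 gives 340 nM; the step is a 1.5-fold higher number from compound 1 to compound 2 (0.19 log units; within the scatter). Compound 3 `CCOc1ccc(-c2cccc(COc3ccc(OCC(=O)O)c(F)c3)c2)cc1` has a different core, with 4-ethoxyphenyl in place of 5-ethoxy-2-methylphenyl on an aromatic carbon; in this assay compound 3 gives 360 nM, and the step is a 1.6-fold higher number from compound 1 to compound 3 (0.21 log units; within the scatter). All three numbers lie within the scatter of one another.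

Compound 4 `O=C(O)COc1ccc(OCc2cccc(-c3ccc(OCC4CC4)cc3)c2)cc1F` is not yet measured and carries cyclopropyl in place of methyl on a saturated chain carbon bound to an oxygen on an aromatic ring on the core of compound 3. The place, on a saturated chain carbon bound to an oxygen on an aromatic ring, is the same word for word in both pairs, so this is the same change that turned compound 1 into compound 2, now made on the core of compound 3. That change occurs only twice among the compounds shown, once measured.

The step in this assay for compound 4 is expected to be a 1.5-fold higher number from compound 3 to compound 4 (0.18 log units; within the scatter), set beside the earlier 1.5-fold higher number from compound 1 to compound 2 (0.19 log units; within the scatter), because a 1.5-fold higher number from compound 1 to compound 2 (0.19 log units; within the scatter) lies within the scatter and there is one example only. Compound 4 is estimated at 540 nM in this assay, with the range 250 nM to 1200 nM.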

Compound 4, half-maximal effective concentration: 540 nM
Beside the measured number, compound 4's estimate shows no gap at the digits printed; measured number inside the range.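

In this assay the change from ethoxy to cyclopropylmethoxy gives a 1.5-fold higher number from compound 3 to compound 4 (0.18 log units; within the scatter). Read on two cores, the change gives steps that do not differ: the same change on two cores in this assay, a 1.5-fold higher number (0.19 log units; within the scatter) from compound 1 to compound 2 and a 1.5-fold higher number (0.18 log units; within the scatter) from compound 3 to compound 4, 1.0-fold (0.01 log units) apart, within the scatter of two such steps. This shows that, on these two cores, the step stays within the scatter whether or not the methyl of the core of compound 1 is present; it does not show that cyclopropylmethoxy shifts the number in either direction, and two pairs give no rule for other cores in the series.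

The compounds shown leave open whether any other group at this place, such as a longer chain like butoxy, a hydroxyl or an amine, would give a step beyond the scatter. They also leave open how the change from ethoxy to cyclopropylmethoxy reads on a core carrying a group other than methyl, such as chloro or trifluoromethyl.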